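Swapping the Aryl Group of a Soluble Quinoline Amine

The compounds below may be only part of what the source reports. "The series", "measured", "known", "first", "only" and "open" are said of these compounds alone.

Compound 1 `COc1cccc(CNCCCNc2ccnc3cc(-c4ccc(C(C)(C)C)cc4)ccc23)c1O` was tested in a physicochemical assay for solubility, with a stated time of 18 h, at pH 7.4 (a higher number here means a more soluble compound, a lower number a less soluble compound), where compound 1 gives 32000 nM. Its nearest neighbour, compound 2 `CC(C)(C)c1ccc(-c2ccc3c(NCCCNCc4ccco4)ccnc3c2)cc1`, gives 32000 nM in this assay. The step of no change at the digits printed from compound 1 to compound 2 (within the scatter) shows that exchanging furan-2-yl for 2-hydroxy-3-methoxyphenyl on a saturated chain carbon bound to an amine nitrogen left the reading unchanged, so on the numbers shown compound 1 stands level with compound 2.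

Compound 3 `COc1cccc(CNCCCNc2ccnc3cc(Cc4ccc(F)cc4Cl)ccc23)c1O` has not yet been measured. It differs from compound 1 on an aromatic carbon of the shared core: 2-chloro-4-fluorobenzyl in place of 4-(tert-butyl)phenyl on an aromatic carbon. For the measured compounds named here, no measured step touches that part of the molecule; the only step measured, from compound 1 to compound 2, altered a different part and was flat. That leaves nothing to argue for a shift in either direction, so the expectation is a step no larger than the scatter, no change at the digits printed from compound 1 to compound 3 (within the scatter). For compound 3 the estimated solubility is 32000 nM, with a range from 14000 nM to 70000 nM.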

Compound 3, solubility: 4200 nM
For compound 3 the middle estimate is 7.6-fold (0.88 log units) above the measured one; measured number outside the range, below it.
By their numbers in this assay, from the lowest: compound 3; then compounds 1 and 2 (each within the scatter of the next).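

For the compounds shown here, the group on the aromatic carbon of the shared core, meta to a fused ring and para to a fused ring, is the first place in this short series where this assay moves beyond the scatter: replacing 4-(tert-butyl)phenyl with 2-chloro-4-fluorobenzyl gives a 7.6-fold lower number from compound 1 to compound 3 (0.88 log units; beyond the scatter). Going by these compounds alone, the only earlier step, at the other end of the molecule, gave no change at the digits printed from compound 1 to compound 2 (within the scatter), so the reading is not equally indifferent to changes everywhere on these compounds. No supporting measurement bears on why this swap lowers the number, so the result stands as an observation without an explanation.

The swap alters several things at once, since the entering group brings a fluorine, a chlorine and a different attachment to the core while the tert-butyl group leaves, and these compounds cannot say which of these changes accounts for the step. A plain benzyl group or a 4-fluorophenyl group at this position would begin to separate them, and pairing the 2-chloro-4-fluorobenzyl group with the furan-2-yl side chain would test whether that end stays as flat as it did with 4-(tert-butyl)phenyl.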